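The source may report more compounds than this note shows. Statements on the series, on what has been measured and on what is new or still open speak of the compounds shown alone.

Compound 1 `CCCCCCc1ccc(COc2cccc(C(=O)NO)c2)cc1` gives 2110 nM in an assay on isolated protein for inhibition of sphingomyelin phosphodiesterase (Homo sapiens), read by fluorescence, with a stated time of 30 min; on this read-out higher numbers stand for weaker inhibition and lower numbers for stronger inhibition.
Compound 2 `O=C(NO)c1cccc(OCc2ccc(-c3cccnc3)cc2)c1` gives 52300 nM.
Compound 3 `CCc1nc(-c2ccc(COc3cccc(C(=O)NO)c3)cc2)no1` gives 34700 nM.

Compound 3 stands second highest of these three numbers. Its nearest neighbour is compound 2, with a 1.5-fold lower number from compound 2 to compound 3 (0.18 log units; within the scatter); its furthest is compound 1, with a 16-fold higher number from compound 1 to compound 3 (1.22 log units; beyond the scatter). Compound 4 `O=C(NO)c1cccc(OCc2ccc(-c3noc(Cc4ccccc4)n3)cc2)c1` differs from compound 3 by phenyl in place of methyl on a saturated chain carbon bound to an aromatic carbon. Neither measured step touches this place: a 25-fold higher number from compound 1 to compound 2 (1.39 log units; beyond the scatter) and a 16-fold higher number from compound 1 to compound 3 (1.22 log units; beyond the scatter) both swap the group on the aromatic carbon, and both were large. Compound 1 does show that a longer carbon chain goes with a lower number, which points, weakly, downward. A modest step is therefore expected, a 1.7-fold lower number from compound 3 to compound 4 (0.24 log units; within the scatter), and compound 4 is estimated at 20000 nM, between 6000 nM and 70000 nM.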

Compound 4, half-maximal inhibitory concentration: 7830 nM
The estimate for compound 4 lay 2.6-fold (0.41 log units) above the measured number; the range from low to high includes it.
By their numbers in this assay, from the lowest: compound 1; then compound 4; then compounds 3 and 2 (each within the scatter of the next).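

This is the first change shown at this place, on a saturated chain carbon bound to an aromatic carbon: going from ethyl to benzyl gives a 4.4-fold lower number from compound 3 to compound 4 (0.65 log units; beyond the scatter) and carries the number beyond the scatter. So the group at this place affects inhibition, and a larger group with an aromatic ring is tolerated here. No measurement shown explains this change.

Still open, from the compounds shown here alone, is whether the ring itself matters or simply the added carbons. A cyclohexyl group or a longer chain at this place would separate the two.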